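Exchanging the Sulfonyl Aryl Group from Compound 1 to Compound 4

The source may report more compounds than this note shows. Statements on the series, on what has been measured and on what is new or still open speak of the compounds shown alone.

compound 1 `CC1CCN(c2c(S(=O)(=O)c3ccc(F)c(F)c3)cnc3c(F)cccc23)CC1`: 93%
compound 2 `Cc1ccc2ncc(S(=O)(=O)c3cc(Cl)cc(Cl)c3)c(N3CCC(C)CC3)c2c1`: 75%
compound 3 `NS(=O)(=O)N1CCN(c2c(S(=O)(=O)c3cccc(F)c3)cnc3cc(F)ccc23)CC1`: 1.9%

In an assay on isolated protein for displacement of a labelled ligand from metabotropic glutamate receptor 5 (Homo sapiens), with a stated time of 60 min, tested at 1 uM (a higher number here means more inhibition at the concentration tested (going by the name of the read-out), a lower number less inhibition), compound 1 gives 93%, the highest of the three numbers; compound 2 lies lower by a margin beyond the scatter, and compound 3 lower still, far beyond it. Compound 4 `Cc1ccc(S(=O)(=O)c2cnc3c(F)cccc3c2N2CCC(C)CC2)cc1` differs from compound 1 in one place: 4-methylphenyl in place of 3,4-difluorophenyl on a sulfonyl sulfur. Within the data shown here, no measured pair shows this exchange, so the size of the step is open. Because compound 2, with another aryl group on its sulfonyl sulfur, still gives 75%, a high number is expected for compound 4 as well. Compound 4 is expected to give about 85%, between 60% and 97%. The estimated step from compound 1 to compound 4 is a number 8 percentage points lower from compound 1 to compound 4 (within the scatter), a small drop that may stay within the scatter.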

Compound 4, a percentage reported as inhibition, at one concentration (the size of the read-out at that concentration, not a potency): 93%
Compound 4: middle estimate off by 8 percentage points, on the low side, within the range that was stated.
By their numbers in this assay, from the lowest: compound 3; then compound 2; then compounds 1 and 4 (each within the scatter of the next).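

Putting 4-methylphenyl in place of 3,4-difluorophenyl on a sulfonyl sulfur gives, in this assay, no change at the digits printed from compound 1 to compound 4 (within the scatter). This single change shows that, on the core of compound 1, the read-out does not depend on keeping the 3,4-difluorophenyl group. Nothing measured here explains why these two groups read alike.

A reading at one concentration leaves open whether the two compounds also match in potency. Also open, as far as these compounds go, is how an aryl group carrying an amine or a carboxylic acid would fare on that sulfonyl sulfur.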